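The source may hold more compounds than are shown below. What is called first, only, known or untested is meant among the compounds shown, and "the series" means these compounds.

Going by the values given here, compound 1, with the structure `O=C(NNC(=O)c1cccc(Cl)c1)c1ccc(NS(=O)(=O)c2cnc(O)nc2O)cc1`, is one of three compounds measured in a functional assay on A549 cells (Homo sapiens) for antiproliferative activity, read by MTT assay, with a stated time of 24 h; on this read-out lower numbers stand for stronger inhibition and higher numbers for weaker inhibition. In this assay compound 1 gives 2290 nM. Compound 2, with the structure `O=C(NNC(=O)c1ccccc1F)c1ccc(NS(=O)(=O)c2cnc(O)nc2O)cc1`, differs from compound 1 in a single place: 2-fluorophenyl in place of 3-chlorophenyl on a carbonyl carbon. That change moved the read-out by a 3.3-fold higher number from compound 1 to compound 2 (0.52 log units; beyond the scatter), so compound 2 gives 7610 nM.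

Compound 3, with the structure `O=C(NNC(=O)c1ccccc1NS(=O)(=O)c1cnc(O)nc1O)c1cccc(Cl)c1`, is built from the same atoms as compound 1 joined in a different way; the difference between the two cores is not broken down here. In this assay compound 3 gives 1260 nM, a number close to that of compound 1 and a good deal lower than that of compound 2.

Compound 4, with the structure `O=C(NNC(=O)c1ccccc1NS(=O)(=O)c1cnc(O)nc1O)c1ccccc1F`, has not yet been measured. It stands to compound 3 as compound 2 stands to compound 1: 2-fluorophenyl in place of 3-chlorophenyl on a carbonyl carbon. The place of the change is described in the same words for both pairs, so it is the same change carried onto the core of compound 3.

Because the same change gave a 3.3-fold higher number from compound 1 to compound 2 (0.52 log units; beyond the scatter), the step from compound 3 to compound 4 in this assay is expected to be about a 3.3-fold higher number from compound 3 to compound 4 (0.52 log units; beyond the scatter). Among the compounds with values here, compound 4 is therefore estimated to give around 4200 nM, most likely between 1800 nM and 9500 nM, resting on only one earlier example of the change.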

Compound 4, half-maximal inhibitory concentration: 7150 nM
For compound 4 the middle estimate is 1.7-fold (0.23 log units) below the measured one; low and high end bracket the measured number.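

In this assay, putting 2-fluorophenyl in place of 3-chlorophenyl on the second core gave a 5.7-fold higher number from compound 3 to compound 4 (0.75 log units; beyond the scatter), so inhibition became weaker there as well. The change therefore carried over from one core to the other in direction, and the two steps cannot be told apart in size: the same change on two cores in this assay, a 3.3-fold higher number (0.52 log units; beyond the scatter) from compound 1 to compound 2 and a 5.7-fold higher number (0.75 log units; beyond the scatter) from compound 3 to compound 4, 1.7-fold (0.23 log units) apart, within the scatter of two such steps. This does not show why the change weakens inhibition, or that it would do the same on a third core, and it cannot separate the effect of the halogen from that of its place on the ring, as both change together in this single swap.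

The compounds shown leave open how 2-chlorophenyl or 3-fluorophenyl would compare, since each of these would change only the halogen or only its place on the ring relative to the groups tested here. From the compounds shown here alone, they also leave open what a plain phenyl, or a phenyl carrying an amine or a carboxylic acid, would give on either core, so the reach of this result beyond the two halogen-bearing groups remains unknown.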